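A few compounds are considered here, and "the series" means these few. Any claim that something is new, unique, unknown or untested is made for them only; others in the source may bear on it.

Measured so far in a functional assay (plasma) with Oryctolagus cuniculus as the target; on this read-out lower numbers stand for stronger inhibition and higher numbers for weaker inhibition

Compound 1 `Cc1nc2cnccc2n1CC1CCN(C(=O)CNC(c2ccccc2)c2ccccc2)CC1` gives 13 nM
Compound 2 `Cc1nc2cnccc2n1CC1CCN(C(=O)CC(C)c2ccccc2)CC1` gives 12 nM
Compound 3 `COC/C(=C\C(=O)N1CCC(Cn2c(C)nc3cnccc32)CC1)c1ccccc1` gives 18 nM

Compound 2 holds the lowest of the three numbers (12 nM), but this gives it no real rank. Compound 1 and compound 3 both lie within the scatter of it, so the three values cannot be put in order.

The next compound to be read is compound 4 `Cc1nc2cnccc2n1CC1CCN(C(=O)CN(C)c2ccccc2)CC1`, which has methyl(phenyl)amino in place of the 1-phenylethyl of compound 2, on a saturated chain carbon bound to a carbonyl carbon (methyl(phenyl)amino in place of 1-phenylethyl on a saturated chain carbon bound to a carbonyl carbon). Among the compounds with values here, no measured pair shows this exchange, so there is no direct precedent for its size or direction.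

The expectation therefore rests on the values alone. Within the data shown here, compound 1 (13 nM) and compound 3 (18 nM) stay within the scatter of compound 2 (12 nM), and the series so far shows no wide spread. The expected step (a 1.7-fold higher number from compound 2 to compound 4 (0.22 log units; within the scatter)) stays within the scatter, with only a slight lean toward a higher number in this assay and no firm direction.

The estimate for compound 4 is 20 nM with an expected range of 7 nM to 60 nM for the measurement still to come.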

Compound 4, half-maximal inhibitory concentration: 23 nM
For compound 4 the middle estimate is 1.2-fold (0.06 log units) below the measured one; the measured number falls inside the stated range.
By their numbers in this assay, from the lowest: compounds 2, 1, 3 and 4 (each within the scatter of the next).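

In this assay, within the data shown here, methyl(phenyl)amino in place of 1-phenylethyl on a saturated chain carbon bound to a carbonyl carbon gives the first step that can be read at a single place (a 1.9-fold higher number from compound 2 to compound 4 (0.28 log units; within the scatter)). The exchange keeps the count of heavy atoms and the six-membered aromatic ring of carbon only, while one carbon gives way to a nitrogen and one hydrogen-bond acceptor enters, and this read-out does not separate the two compounds. Nothing at hand bears on a cause for this result.

Still open, from the compounds shown here alone, is whether any group at this place can carry the number beyond the scatter, since a single exchange that stays within it says little about the range the position allows; a carboxylic acid or a longer chain on the same saturated chain carbon would test that. Also open, going by these compounds, is phenylamino, with a hydrogen in place of the methyl of methyl(phenyl)amino, which would show whether that methyl counts for anything.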